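A Thiazole Ring in Place of a Branched Alkene

This account rests on a few compounds, and the source may have more. Where it says the series, first, only, none or still open, it means among the compounds named here.

Compound 3 `CCCCNc1nc(N)nc2ccn(CC=C(C)C)c12` shares its core with compound 1 `CCCCNc1nc(N)nc2ccn(CCCc3ccccc3)c12` and compound 2 `CCCCNc1nc(N)nc2ccn(CC(=O)NC)c12`; the three differ only in the group on a saturated chain carbon bound to an aromatic nitrogen. In an assay on HEK293 cells for agonist activity at Toll-like receptor 8 (Homo sapiens), read by a luciferase reporter, with a stated time of 6 h (a higher number here means that more compound is needed for the effect, a lower number that less compound is needed), compound 1 gives 3.78 uM. Compound 2 gives only a limit of the assay, > 25 uM. Compound 3 likewise gives only a limit, > 25 uM, so compound 3 stands at the edge where the assay stops reporting a number, as described by the limit of > 25 uM in this assay, at which 2 of the 3 values shown sit.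

The unmeasured compound 4 `CCCCNc1nc(N)nc2ccn(Cc3nccs3)c12` differs from compound 3 in one place: 1,3-thiazol-2-yl in place of 2-methylprop-1-en-1-yl on a saturated chain carbon bound to an aromatic nitrogen. Within the data shown here, two measured steps touch this position: an at least 6.6-fold higher number from compound 1 to compound 3 (0.82 log units; beyond the scatter) and an at least 6.6-fold higher number from compound 1 to compound 2 (0.82 log units; beyond the scatter). The step that the two limits leave unreadable from compound 2 to compound 3 cannot be sized, since both of its ends sit at the limit. Compound 4 restores an aromatic ring, which compound 1 carries and compound 3 lacks, so a move back toward a measurable number is expected, though how far is uncertain. The step from compound 3 to compound 4 is expected to be an at least 2.5-fold lower number from compound 3 to compound 4 (0.39 log units; beyond the scatter) in this assay. Compound 4 is estimated to give 10 uM, within a range from 2 uM to 50 uM.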

Compound 4, minimum effective concentration: 2.27 uM
Estimate against measurement, compound 4: 4.4-fold (0.64 log units) above, and the stated range covers the measured number.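

In this assay, placing 1,3-thiazol-2-yl on the saturated chain carbon bound to an aromatic nitrogen brings back a readable number, with an at least 11-fold lower number from compound 3 to compound 4 (1.04 log units; beyond the scatter) and an at least 11-fold lower number from compound 2 to compound 4 (1.04 log units; beyond the scatter). The earlier compounds shown here showed one aromatic group giving a number at this position; this result adds a second, smaller one with hetero atoms, and it cannot be told apart from phenethyl, with a 1.7-fold lower number from compound 1 to compound 4 (0.22 log units; within the scatter). Among these four compounds, the two that carry an aromatic ring give numbers and the two without one sit at a limit, and the true sizes of the steps starting from those two stay unknown because each step starts from a limit rather than a number: the limit of > 25 uM in this assay, at which 2 of the 4 values shown sit.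

The compounds shown leave open whether the nitrogen and sulfur of the thiazole ring matter or any aromatic ring would do, a question that a plain phenyl or a 2-pyridyl group on the same chain carbon could answer. Also open, on these data alone, is whether an amine or a carboxylic acid on the thiazole ring would keep a readable number.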